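Nitro in Place of Methoxy at the Assay Limit

This account rests on a few compounds, and the source may have more. Where it says the series, first, only, none or still open, it means among the compounds named here.

Compound 1 `CCOC(=O)C1=Cc2ccccc2OC1(OCc1cc(-c2ccc(C)cc2)no1)C(F)(F)F` in a functional assay on HeLa cells (Homo sapiens) for inhibition, read by MTT assay, with a stated time of 24 h (on this read-out lower numbers stand for stronger inhibition and higher numbers for weaker inhibition), gives > 150000 nM, a limit of the assay rather than a number.
Compound 2 `CCOC(=O)C1=Cc2ccccc2OC1(OCc1cc(-c2ccc(OC)cc2)no1)C(F)(F)F` in this assay gives > 150000 nM, again a limit and not a number.

The two measured compounds differ in one place, and the step from compound 1 to compound 2 reads a step that the two limits leave unreadable from compound 1 to compound 2; both values sit at the limit of > 150000 nM in this assay, at which 2 of the 2 values shown sit, so its size cannot be read. Among the measured compounds shown here, compound 2 thus stands only at a limit, and the one further value shown is likewise a limit. Compound 3 `CCOC(=O)C1=Cc2ccccc2OC1(OCc1cc(-c2ccc([N+](=O)[O-])cc2)no1)C(F)(F)F` has not yet been measured in this assay. It differs from compound 2 by nitro in place of methoxy on an aromatic carbon. For the measured compounds named here, the only measured step touching this position is of unreadable size, so no direction can be taken from it. Because compound 2 gives > 150000 nM as a limit, compound 3 is expected to sit near that same limit, with an expected step that the limit leaves unreadable from compound 2 to compound 3, none beyond the scatter. Compound 3 is accordingly estimated at 200000 nM, ranging from 60000 nM to 700000 nM.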

Compound 3, half-maximal inhibitory concentration: > 150000 nM
Compound 3: no number, only a limit (the forecaster's own chance of this, stated with the estimate: 80%); the middle value is on the limit's open side.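

In this assay compound 3 gives > 150000 nM, a limit and not a number. No step among compound 1, compound 2 and compound 3 can be read, because all three stand at the same limit: the limit of > 150000 nM in this assay, at which 3 of the 3 values shown sit.

The compounds shown leave open how strongly any of them inhibits, and whether methyl, methoxy or nitro on the aromatic carbon makes any difference.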